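Aryl Variation on the Amide Carbonyl Across Four Analogues

The source may report more compounds than this note shows. Statements on the series, on what has been measured and on what is new or still open speak of the compounds shown alone.

Measured compounds:
compound 1, `O=C(Nc1cccc(-c2oc3cc(-c4ccc(F)cc4)ccc3c(=O)c2O)c1)c1ccc(F)cc1`, 14600 nM
compound 2, `O=C(Nc1cccc(-c2oc3cc(-c4ccc(F)cc4)ccc3c(=O)c2O)c1)c1cccc(F)c1`, 15800 nM
compound 3, `COc1cc(OC)cc(C(=O)Nc2cccc(-c3oc4cc(-c5ccc(F)cc5)ccc4c(=O)c3O)c2)c1`, 19600 nM

In a functional assay on GTL 16 cells for antiproliferative activity against GTL 16 cell line (Homo sapiens), read by CCK-8 assay, with a stated time of 72 h (on this read-out lower numbers stand for stronger inhibition and higher numbers for weaker inhibition), compound 3 gives the highest of the three numbers, but its steps to both neighbours sit within the scatter: a 1.3-fold higher number from compound 1 to compound 3 (0.13 log units; within the scatter) and a 1.2-fold higher number from compound 2 to compound 3 (0.09 log units; within the scatter). Compound 4, `N#Cc1ccc(C(=O)Nc2cccc(-c3oc4cc(-c5ccc(F)cc5)ccc4c(=O)c3O)c2)cc1`, differs from compound 3 only at the carbonyl carbon: 4-cyanophenyl in place of 3,5-dimethoxyphenyl on a carbonyl carbon. The measured steps that bear on this change are the earlier swaps at the same carbon, a 1.1-fold higher number from compound 1 to compound 2 (0.03 log units; within the scatter), a 1.3-fold higher number from compound 1 to compound 3 (0.13 log units; within the scatter) and a 1.2-fold higher number from compound 2 to compound 3 (0.09 log units; within the scatter), none beyond the scatter. Compound 4 is therefore expected to show a step of a 1.2-fold lower number from compound 3 to compound 4 (0.07 log units; within the scatter), with no change beyond the scatter. The estimate for compound 4 in this assay is 16500 nM, expected between 7500 nM and 36000 nM.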

Compound 4, half-maximal inhibitory concentration: 31800 nM
For compound 4 the middle estimate is 1.9-fold (0.28 log units) below the measured one, and the stated range covers the measured number.
By their numbers in this assay, from the lowest: compounds 1, 2, 3 and 4 (each within the scatter of the next, the first and the last beyond it).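

In this assay, this carbonyl position now gives its first step beyond the scatter, a modest one, with cyano in place of fluoro on an aromatic carbon (a 2.2-fold higher number from compound 1 to compound 4 (0.34 log units; beyond the scatter)). Among the compounds shown here, the same group stays within the scatter against the other two aryl groups, both 3,5-dimethoxyphenyl (a 1.6-fold higher number from compound 3 to compound 4 (0.21 log units; within the scatter)) and 3-fluorophenyl (a 2.0-fold higher number from compound 2 to compound 4 (0.30 log units; within the scatter)), so the change separates only this one pair. No evidence is at hand that explains this step.

The compounds shown leave open how a non-aryl group on the carbonyl carbon, such as an amine or a carboxylic acid, would read here. They also leave open whether any aryl group gives a lower number than the fluorinated analogues.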